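The source may hold more compounds than are shown below. What is called first, only, known or untested is meant among the compounds shown, and "the series" means these compounds.

Measured compounds:
Compound 1, `CCCn1ccc2cc(/C(C)=C/C(=O)Nc3ccccc3OCCCC(=O)O)ccc21`, gives 190 nM in an assay on Prostate gland for inhibition of steroid 5-alpha-reductase (Rattus norvegicus); on this read-out higher numbers stand for weaker inhibition and lower numbers for stronger inhibition.
Compound 2, `CCCCCCCn1ccc2cc(/C(C)=C/C(=O)Nc3ccccc3OCCCC(=O)O)ccc21`, gives 120 nM in this assay.
Compound 3, `CC(C)=CCn1ccc2cc(/C(C)=C/C(=O)Nc3ccccc3OCCCC(=O)O)ccc21`, gives 120 nM in this assay.

All three share the same core and differ only in the chain carried on the aromatic nitrogen. Compound 3 stands level with compound 2 at the digits shown, and the two together hold the lowest numbers of the three; the gap between the two ends of the set is a 1.6-fold lower number from compound 1 to compound 3 (0.20 log units; within the scatter), so no ordering among them can be claimed.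

Compound 4, `CCCCC(CCCC)n1ccc2cc(/C(C)=C/C(=O)Nc3ccccc3OCCCC(=O)O)ccc21`, is not yet measured. It differs from compound 3 in this way: 1-butylpentyl in place of 3-methylbut-2-en-1-yl on an aromatic nitrogen. Among the measured compounds shown here, the steps that bear on this change are those at the same position. From compound 1 to compound 2, a 1.6-fold lower number from compound 1 to compound 2 (0.20 log units; within the scatter). From compound 2 to compound 3, no change at the digits printed from compound 2 to compound 3 (within the scatter). Neither lengthening the chain nor swapping a saturated chain for one with a double bond moved the number beyond the scatter. For the measured compounds named here, a branched nine-carbon chain has no direct precedent here, yet nothing among the measured steps points to a shift. For compound 4 the expected step is therefore a 1.1-fold higher number from compound 3 to compound 4 (0.03 log units; within the scatter), none beyond the scatter. Compound 4 is estimated at 130 nM, within the range 50 nM to 350 nM.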

Compound 4, half-maximal inhibitory concentration: 21 nM
For compound 4 the middle estimate is 6.2-fold (0.79 log units) above the measured one; the measured number lies below the stated range.
By their numbers in this assay, from the lowest: compound 4; then compounds 2, 3 and 1 (each within the scatter of the next).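

At this position the chain now makes a clear difference in this assay: 1-butylpentyl gives a step beyond the scatter against 3-methylbut-2-en-1-yl (a 5.7-fold lower number from compound 3 to compound 4 (0.76 log units; beyond the scatter)), against heptyl (a 5.7-fold lower number from compound 2 to compound 4 (0.76 log units; beyond the scatter)) and against propyl (a 9.0-fold lower number from compound 1 to compound 4 (0.96 log units; beyond the scatter)), whereas the three earlier chains could not be told apart. The step from heptyl is the most informative, as both groups are saturated open chains and the branched one carries the lower number. No measurement here explains why this chain stands apart.

With a single branched chain, the effect of branching cannot be separated from that of the added carbons. An unbranched nonyl chain, a shorter branched chain such as isopropyl, or a ring such as cyclohexyl would help to separate them.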